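A few compounds are considered here, and "the series" means these few. Any claim that something is new, unique, unknown or untested is made for them only; others in the source may bear on it.

Of the compounds shown here, two have so far been measured in a physicochemical assay for solubility, measured as thermodynamic solubility; a higher number here means a more soluble compound, a lower number a less soluble compound. Compound 1, `COc1ccc(OC)c(-c2ccc(NC(=O)c3ccncc3F)cc2)c1`, gives 0.28 ug/mL in this assay. Compound 2, `COc1cccc(-c2ccc(-n3cc(-c4cccc(C(=O)O)c4)nn3)cc2)c1`, gives 856 ug/mL in this assay. Going by the values given here, of these two numbers compound 2 holds the higher one, and its only neighbour, compound 1, sits far lower; since the two structures differ in several places at once, only the two values themselves can be set side by side. Compound 3, `COc1cccc(-c2ccc(-n3cc(-c4cccc(C(=O)O)c4)nn3)cc2)c1OC`, has not yet been measured. It differs from compound 2 in a single place: methoxy in place of hydrogen on an aromatic carbon. Among the compounds with values here, no step between measured compounds that differ in one place is available to guide the expectation. For compound 3 the change is expected to move solubility little, downward if at all, so the step of a 1.7-fold lower number from compound 2 to compound 3 (0.23 log units; within the scatter) is estimated to stay within the usual scatter. Compound 3 is therefore estimated to give 500 ug/mL in this assay, with a range from 150 ug/mL to 1500 ug/mL.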

Compound 3, solubility: 1530 ug/mL
Estimate against measurement, compound 3: 3.1-fold (0.49 log units) below; the whole stated range lies below it.
By their numbers in this assay, from the lowest: compound 1; then compounds 2 and 3 (each within the scatter of the next).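

In this assay, going by these compounds alone, putting methoxy in place of hydrogen on an aromatic carbon, ortho to a large group and ortho to a methoxy group, gives a 1.8-fold higher number from compound 2 to compound 3 (0.25 log units; within the scatter) and so provides the first step between compounds that differ in one place. The change from 3-methoxyphenyl to 2,3-dimethoxyphenyl therefore leaves two numbers that cannot be told apart, so at this position the extra methoxy shows no measurable effect on the read-out. No measurement here offers an explanation for this result.

The compounds shown leave open whether a different group at this same place, such as an amine or a longer chain like ethoxy, would also leave the number within the scatter. They also leave open whether methoxy would behave the same way on other carbons of this ring.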